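The source may hold more compounds than are shown below. What is called first, only, known or untested is meant among the compounds shown, and "the series" means these compounds.

Measured in an ADME assay on HepG2 2.2.15 cells (Homo sapiens) for cytotoxicity, read by CCK-8 assay, with a stated time of 8 days; on this read-out higher numbers stand for lower toxicity in this test and lower numbers for higher toxicity in this test:
- compound 1 `COc1ccc(-c2cc(NC(=O)c3ccc(OC)cc3O)c[nH]c2=O)cc1`: 49900 nM
- compound 2 `COc1ccc(-c2cc(NC(=O)c3ccc(Cl)cc3O)c[nH]c2=O)cc1`: 50500 nM
- compound 3 `COc1ccc(C(=O)Nc2c[nH]c(=O)c(-c3cccc(C)c3)c2)c(O)c1`: > 100000 nM

Compound 3 has no number in this assay, only a limit (the limit of > 100000 nM in this assay, at which 1 of the 3 values shown sits).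

Next is compound 4 `Cc1cccc(-c2cc(NC(=O)c3ccc(F)cc3O)c[nH]c2=O)c1`, which has not been measured. Its difference is fluoro in place of methoxy on an aromatic carbon.

The closest measured change is a 1.0-fold higher number from compound 1 to compound 2 (0.01 log units; within the scatter). It also replaces methoxy on an aromatic carbon, though with chloro, and in compounds carrying 4-methoxyphenyl rather than 3-methylphenyl. The other measured step is an at least 2.0-fold higher number from compound 1 to compound 3 (0.30 log units; that floor lies within the scatter), and it concerns the aryl group, which stays unchanged here. For the measured compounds named here, no measured compound carries fluoro, so the expectation rests on the chloro step alone. On that basis, no change beyond the scatter is expected in this assay.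

The estimated change is an at least 1.1-fold lower number from compound 3 to compound 4 (0.07 log units; that floor lies within the scatter), and a result reported only as a limit remains quite possible. For compound 4 the expected value is 85000 nM, with an estimated range from 40000 nM to 150000 nM.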

Compound 4, half-maximal cytotoxic concentration: 37200 nM
Estimate against measurement, compound 4: 2.3-fold (0.36 log units) above; the measured number lies below the stated range.
By their numbers in this assay, from the lowest: compounds 4, 1 and 2 (each within the scatter of the next). At a limit, above all of these: compound 3.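

At the position para to a large group and meta to a hydroxy group, replacing methoxy does not always leave this assay unmoved: with 3-methylphenyl on the core, fluoro in place of methoxy gives an at least 2.6-fold lower number from compound 3 to compound 4 (0.42 log units; beyond the scatter). The earlier replacement at this position, chloro in place of methoxy with 4-methoxyphenyl on the core, gave a 1.0-fold higher number from compound 1 to compound 2 (0.01 log units; within the scatter), so the two steps differ in both the entering group and the aryl group. The new step is only a floor, since compound 3 has a limit and not a number: the limit of > 100000 nM in this assay, at which 1 of the 4 values shown sits.

The compounds shown leave open whether fluoro gives a similar step with 4-methoxyphenyl on the core, and whether chloro does with 3-methylphenyl. Going by these compounds, how an amine or a carboxylic acid at this position would read in this assay also stays open.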